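A Sulfamoyl Group Enters Where Fluoro Left

A few compounds are considered here, and "the series" means these few. Any claim that something is new, unique, unknown or untested is made for them only; others in the source may bear on it.

Compound 1 `N#CC1=C(N)Oc2c(c3nc4ccccc4nc3c3ccccc23)C12C(=O)N(Cc1cnnn1-c1ccc(F)cc1)c1ccccc12` carries a 4-fluorophenyl on an aromatic nitrogen of the shared core. In a functional assay on A549 cells (Homo sapiens) for antiproliferative activity, read by MTT assay, with a stated time of 48 h (a higher number here means a weaker inhibitor, a lower number a stronger inhibitor), compound 1 gives > 50000 nM, which is a limit of the assay rather than a number. Compound 1 therefore stands at the limit of > 50000 nM in this assay, at which 1 of the 2 values shown sits. Compound 2 `N#CC1=C(N)Oc2c(c3nc4ccccc4nc3c3ccccc23)C12C(=O)N(Cc1cnnn1-c1cccc(Cl)c1)c1ccccc12` has 3-chlorophenyl in place of 4-fluorophenyl on that nitrogen, and in this assay compound 2 gives 32600 nM. Among the compounds with values here, the only measured comparison is an at least 1.5-fold lower number from compound 1 to compound 2 (0.18 log units; that floor lies within the scatter), a change of the aryl substituent that stayed within the scatter. Compound 3 `N#CC1=C(N)Oc2c(c3nc4ccccc4nc3c3ccccc23)C12C(=O)N(Cc1cnnn1-c1ccc(S(N)(=O)=O)cc1)c1ccccc12` is the unmeasured member; it differs from compound 1 by sulfamoyl in place of fluoro on an aromatic carbon, para to a large group. Within the data shown here, no measured step exchanges fluoro for sulfamoyl, so the aryl-substituent step just described is the nearest guide. The step from compound 1 to compound 3 in this assay is accordingly expected to remain within the scatter, as an at least 1.2-fold lower number from compound 1 to compound 3 (0.09 log units; that floor lies within the scatter). Compound 3 is estimated at 40000 nM, between 15000 nM and 100000 nM.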

Compound 3, half-maximal inhibitory concentration: > 50000 nM
Compound 3 ended at the assay's limit; the forecaster's own chance of this, stated with the estimate: 45%; at least 1.2-fold (0.09 log units) between middle value and limit.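

Compound 3 adds a second aryl group on this nitrogen whose reading is a limit of this assay and not a number: the limit of > 50000 nM in this assay, at which 2 of the 3 values shown sit. The exchange of fluoro for sulfamoyl therefore cannot be sized, as compound 1 and compound 3 are both limits. The only readable step is an at least 1.5-fold higher number from compound 2 to compound 3 (0.18 log units; that floor lies within the scatter), so a sulfamoyl group on this aromatic carbon, para to a large group, gives no reading that can be shown to stand clear of the scatter.

From the compounds shown here alone, whether an amine or a carboxylic acid at this place would give a reading well inside the range of this assay stays open. Also open, going by these compounds, is how far the true values of compound 1 and compound 3 lie past their limits, and so whether the two differ at all.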